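The source may hold more compounds than are shown below. What is called first, only, known or untested is meant among the compounds shown, and "the series" means these compounds.

The shared core is seen in compound 1 `COc1cc2c(Oc3ccc(/C=N/NC(=O)Nc4ccccc4)cc3F)ccnc2cc1OCCCN1CCCCC1`, which in a functional assay on A549 cells (Homo sapiens) for cytotoxicity, read by MTT assay, with a stated time of 72 h (a higher number here means a weaker inhibitor, a lower number a stronger inhibitor), gives 280 nM. Compound 2 `COc1cc2c(Oc3ccc(/C=N/NC(=O)Nc4ccc(F)c(F)c4)cc3F)ccnc2cc1OCCCN1CCCCC1` in this assay gives "not determined" (no result reported), and compound 3 `COc1cc2c(Oc3ccc(/C=N/NC(=O)Nc4ccc(Br)cc4)cc3F)ccnc2cc1OCCCN1CCCCC1` in this assay likewise gives "not determined" (no result reported). Compound 3 therefore stands without a number of its own; the only figure in the set belongs to compound 1. Compound 4 `COc1cc2c(Oc3ccc(/C=N/NC(=O)Nc4ccc(F)cc4Br)cc3F)ccnc2cc1OCCCN1CCCCC1` differs from compound 3 by 2-bromo-4-fluorophenyl in place of 4-bromophenyl on an amide-type nitrogen. For the measured compounds named here, no step between two measured compounds is available, so the size of this change cannot be read from the data; the expectation is a step of no more than the usual scatter, in no fixed direction, anchored on the value of compound 1. Compound 4 is expected to give 350 nM in this assay, with a range from 100 nM to 1500 nM.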

Compound 4, half-maximal inhibitory concentration: 98 nM
The estimate for compound 4 lay 3.6-fold (0.55 log units) above the measured number; measured number outside the range, below it.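

In this assay, for the compounds shown here, the group on the amide-type nitrogen proves able to shift the number: 2-bromo-4-fluorophenyl in place of phenyl gives a 2.9-fold lower number from compound 1 to compound 4 (0.46 log units; beyond the scatter), the first measured step at this position. The steps from compound 2 and compound 3 cannot be read, so the separate contributions of the bromine and the fluorine stay unresolved. No measurement given here accounts for the change. As far as these compounds go, it remains open how an amine or a carboxylic acid on this phenyl ring would read in this assay.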